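Fluoro for Methoxy on the Phenyl of a Piperazinyl Pyrazole

This account rests on a few compounds, and the source may have more. Where it says the series, first, only, none or still open, it means among the compounds named here.

Measured compounds:
Compound 1, `COc1ccc(-c2n[nH]cc2N2CCNCC2)cc1`: > 10000 nM
Compound 2, `Fc1cccc(-c2n[nH]cc2N2CCNCC2)c1`: > 10000 nM

Compound 1 carries a methoxy group on its phenyl ring. In an assay on isolated protein for binding affinity to 5-hydroxytryptamine receptor 4 (Homo sapiens) (a higher number here means a weaker inhibitor, a lower number a stronger inhibitor), compound 1 gives > 10000 nM, which is a limit of the assay and not a measured number. Compound 2 bears a fluoro group on the same ring and shares the rest of the core. In this assay compound 2 gives > 10000 nM, again a limit rather than a number. Compound 1 therefore stands at the edge of what the assay reports, with no ranking possible between it and compound 2, since (the limit of > 10000 nM in this assay, at which 2 of the 2 values shown sit).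

The untested compound 3, `Fc1ccc(-c2n[nH]cc2N2CCNCC2)cc1`, is obtained from compound 1 by a single change: fluoro in place of methoxy on an aromatic carbon.

Among the measured compounds shown here, no step between measured compounds exists to size this change. Given that both measured compounds sit at the limit, the step from compound 1 to compound 3 is expected to be none beyond the scatter, a step that the limit leaves unreadable from compound 1 to compound 3. Compound 3 is estimated at 15000 nM, with a range from 5000 nM to 50000 nM, most likely reported as a limit once more.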

Compound 3, inhibition constant: > 10000 nM
Compound 3 gave a limit, no number; the forecaster's own chance of this, stated with the estimate: 85%; the middle value does not contradict the limit.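

No size can be read for the step from compound 1 to compound 3 in this assay, since both compounds give only a limit of the assay: the limit of > 10000 nM in this assay, at which 3 of the 3 values shown sit.

The compounds shown leave open how strongly any of them binds, and whether fluoro in place of methoxy changes binding at all.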